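The source may hold more compounds than are shown below. What is called first, only, known or untested is meant among the compounds shown, and "the series" means these compounds.

Of the compounds shown here, two have a measured value so far; compound 3 does not. Compound 1 `CC(C)=CCC/C(C)=C/CC/C(C)=C/CC[C@@H]1[C@@]2(C)CC/C(=N\OCc3cn(-c4ccc(Cl)cc4)nn3)C(C)(C)[C@@H]2CC[C@@]1(C)O` gives 19900 nM in a functional assay on HepG2 cells (Homo sapiens) for cytotoxicity, read by MTT assay, with a stated time of 48 h; on this read-out lower numbers stand for stronger inhibition and higher numbers for weaker inhibition. Compound 2 `CC(C)=CCC/C(C)=C/CC/C(C)=C/CC[C@@H]1[C@@]2(C)C/C(=C\c3ccc(OCc4cn(-c5ccccc5)nn4)cc3)C(=O)C(C)(C)[C@@H]2CC[C@@]1(C)O` gives 126000 nM in this assay, the highest of the two numbers; the gap to compound 1 lies beyond the scatter, but the two structures differ in more than one place, so no single step can be read from it. Compound 3 `CC(C)=CCC/C(C)=C/CC/C(C)=C/CC[C@@H]1[C@@]2(C)C/C(=C\c3ccc(OCc4cn(-c5ccncc5)nn4)cc3)C(=O)C(C)(C)[C@@H]2CC[C@@]1(C)O` has not yet been measured. It differs from compound 2 in one place: pyridin-4-yl in place of phenyl on an aromatic nitrogen. Going by the values given here, no measured pair in this set shows what pyridin-4-yl in place of phenyl on an aromatic nitrogen does in this assay, so the expectation rests on compound 2 alone. The expected step, a 1.1-fold lower number from compound 2 to compound 3 (0.06 log units; within the scatter), is small, with neither direction favoured and nothing expected beyond the scatter. Compound 3 is therefore estimated at 110000 nM in this assay, with a range from 40000 nM to 280000 nM, and the measured value will show whether that holds.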

Compound 3, half-maximal inhibitory concentration: 105000 nM
The estimate for compound 3 lay 1.0-fold (0.02 log units) above the measured number, and the stated range covers the measured number.
By their numbers in this assay, from the lowest: compound 1; then compounds 3 and 2 (each within the scatter of the next).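

In this assay, going by these compounds alone, replacing phenyl with pyridin-4-yl on the aromatic nitrogen of the five-membered aromatic ring with 3 nitrogen gives a 1.2-fold lower number from compound 2 to compound 3 (0.08 log units; within the scatter), the first measured single change. By the counts, the exchange swaps one ring carbon for a ring nitrogen and adds one hydrogen-bond acceptor, yet in this pair that change leaves the number within the scatter, so this position shows no readable response to this particular exchange. No measurement at hand accounts for this outcome.

As far as these compounds go, whether another group on that nitrogen, such as pyridin-3-yl, a phenyl ring bearing an amine or a carboxylic acid, or a longer alkyl chain, would move the number beyond the scatter remains open, as one exchange at one position cannot settle it. From the compounds shown here alone, compound 1 differs from compound 2 and compound 3 in more than one place, so its gaps to them cannot be read as steps, and how pyridin-4-yl would behave on the core of compound 1 also remains unknown.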